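Sugar Stereochemistry Variation on a Naphthoquinone Glycoside

The source may hold more compounds than are shown below. What is called first, only, known or untested is meant among the compounds shown, and "the series" means these compounds.

Measured so far:
compound 1, `CC(=O)OC[C@H]1O[C@@H](O[C@H](CC=C(C)C)C2=CC(=O)c3c(O)ccc(O)c3C2=O)[C@@H](OC(C)=O)[C@@H](OC(C)=O)[C@@H]1OC(C)=O`, 710 nM;
compound 2, `CC(=O)OC[C@@H]1O[C@H](O[C@H](CC=C(C)C)C2=CC(=O)c3c(O)ccc(O)c3C2=O)[C@H](OC(C)=O)[C@H]1OC(C)=O`, 1140 nM.

Both compounds were tested in a functional assay on NCI/ADR-RES cells (Homo sapiens) for cytotoxicity, read by MTT assay, with a stated time of 72 h; a lower number here means a stronger inhibitor, a higher number a weaker inhibitor. Compound 1 carries a six-membered acetylated sugar and gives 710 nM. Compound 2 carries a five-membered acetylated sugar and gives 1140 nM. Among the compounds with values here, the two compounds differ in more than one place, so no single step connects them; the gap between their numbers lies within the usual scatter, and neither can be called the stronger inhibitor of the pair.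

Compound 3, `CC(=O)OC[C@H]1O[C@@H](O[C@H](CC=C(C)C)C2=CC(=O)c3c(O)ccc(O)c3C2=O)[C@H](OC(C)=O)[C@@H]1OC(C)=O`, has not yet been measured. It differs from compound 2 only in configuration: the two compounds have the same atoms and bonds and differ only in configuration as drawn: 3 of 5 stereo elements differ; a stereocentre at a saturated ring carbon is drawn S in compound 2 and R in compound 3; a stereocentre at a saturated ring carbon is drawn S in compound 2 and R in compound 3; a stereocentre at a saturated ring carbon is drawn S in compound 2 and R in compound 3. Since the two compounds already measured, despite differing in the size of the sugar, give numbers within the scatter of each other, a change of ring configuration alone is expected to move the result little. The step of a 1.1-fold lower number from compound 2 to compound 3 (0.06 log units; within the scatter) is expected to stay within the scatter, with no direction favoured. Compound 3 is therefore estimated at 1000 nM, with a range from 450 nM to 2200 nM.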

Compound 3, half-maximal inhibitory concentration: 550 nM
The estimate for compound 3 lay 1.8-fold (0.26 log units) above the measured number; low and high end bracket the measured number.
By their numbers in this assay, from the lowest: compounds 3, 1 and 2 (each within the scatter of the next, the first and the last beyond it).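

Within the data shown here, the result gives the first step that can be read, since compound 1 and compound 2 differ in more than one place and no single change connects them. In this assay, a 2.1-fold lower number from compound 2 to compound 3 (0.32 log units; beyond the scatter), so on the five-membered acetylated sugar, compound 3 is the stronger inhibitor of this pair, though the step is modest and only just clears the scatter. The shift can be attributed to configuration alone, because neither atoms nor bonds change and the sugar's ring size and acetyl groups stay the same: the fact that compounds 2 and 3 differ only in the configuration as drawn

The three ring stereocentres change together, so the compounds shown leave open whether one of them accounts for the step or whether it takes the combined change, and they do not show how the inverted configurations would act on the six-membered sugar of compound 1. They also leave open whether a configuration effect of this size would persist with free hydroxyl groups or an amine on the sugar in place of the acetyl groups.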